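Cyclopentyloxy to butoxy on the dibromopyridyl benzamide

The source may report more compounds than this note shows. Statements on the series, on what has been measured and on what is new or still open speak of the compounds shown alone.

Two compounds of the series carry values in an assay on isolated protein for inhibition of phosphodiesterase 4A (Sus scrofa); a higher number here means a weaker inhibitor, a lower number a stronger inhibitor. Compound 1 `CCCCOc1cc(C(=O)Nc2c(F)cccc2F)ccc1OC` gives 300 nM, and compound 2 `COc1ccc(C(=O)Nc2c(Br)cncc2Br)cc1OC1CCCC1` gives 7 nM. Compound 2 therefore stands at the lowest of the two numbers, with compound 1 a good deal higher, well beyond the scatter of repeats in this assay. The two differ in more than one place, so their gap cannot be traced to a single change.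

Compound 3 `CCCCOc1cc(C(=O)Nc2c(Br)cncc2Br)ccc1OC` is not yet measured. It keeps the amide and the dibromopyridyl side of compound 2 and differs only in one place: butyl in place of cyclopentyl on an oxygen on an aromatic ring. Among the measured compounds shown here, no measured pair shows this same change, so the size of the step is an open question. A moderate rise in number, beyond the scatter, is expected, given that compound 2 sits at 7 nM and the change removes the ring. The expected step from compound 2 to compound 3 is a 5.7-fold higher number from compound 2 to compound 3 (0.76 log units; beyond the scatter). Compound 3 is therefore estimated at 40 nM, with a range from 10 nM to 160 nM.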

Compound 3, half-maximal inhibitory concentration: 70 nM
Estimate against measurement, compound 3: 1.8-fold (0.24 log units) below; the measured number falls inside the stated range.
By their numbers in this assay, from the lowest: compound 2; then compound 3; then compound 1.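

In this assay, the change from cyclopentyloxy to butoxy on the dibromopyridyl benzamide now has a size of its own: a 10-fold higher number from compound 2 to compound 3 (1.00 log units; beyond the scatter), so cyclopentyl and butyl on this oxygen are not interchangeable. The group on the amide-type nitrogen also matters separately, with 3,5-dibromopyridin-4-yl in place of 2,6-difluorophenyl giving a 4.3-fold lower number from compound 1 to compound 3 (0.63 log units; beyond the scatter). Nothing available here accounts for either step.

Still open, from the compounds shown here alone, is whether the cyclopentyl step reflects the ring itself or the shape and length of the chain; a propyl or pentyl chain, or a cyclobutyl or cyclohexyl ring, on the same oxygen would help separate these readings. Also open, going by these compounds, is whether the butyl step keeps its size with another group on the nitrogen, such as 2,6-dichlorophenyl.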